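A few compounds are considered here, and "the series" means these few. Any claim that something is new, unique, unknown or untested is made for them only; others in the source may bear on it.

Compound 2 `O=C(CCSc1nnc(-c2ccncc2)s1)NCc1ccccc1`: 14000 nM
Compound 1 `CC(Sc1nnc(-c2ccncc2)s1)C(=O)NCc1ccccc1Cl`: > 50000 nM

In an ADME assay on HepG2 cells (Homo sapiens) for cytotoxicity, with a stated time of 3 days (a higher number here means that more compound is tolerated, a lower number that less compound is tolerated), compound 2 gives 14000 nM, the only plain number among the two results shown. Compound 1 gives > 50000 nM, which is a limit of the assay rather than a number (the limit of > 50000 nM in this assay, at which 1 of the 2 values shown sits). Compound 3 `O=C(CCSc1nnc(-c2ccncc2)s1)Nc1ccc(Cl)cc1Cl` has not yet been measured. It differs from compound 2 in one place: 2,4-dichlorophenyl in place of benzyl on an amide-type nitrogen. Within the data shown here, no measured pair shows a change of this kind, so the size of the step is uncertain; a modest fall in the tolerated concentration, somewhat beyond the scatter, seems the most likely outcome. Compound 3 is therefore expected near 8000 nM, between 3000 nM and 25000 nM. The expected step is a 1.8-fold lower number from compound 2 to compound 3 (0.24 log units; within the scatter).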

Compound 3, half-maximal cytotoxic concentration: > 50000 nM
Compound 3 was reported as a limit (the forecaster's own chance of this, stated with the estimate: 10%); middle value at least 6.2-fold (0.79 log units) from the limit.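

In this assay the swap of benzyl for 2,4-dichlorophenyl gives an at least 3.5-fold higher number from compound 2 to compound 3 (0.55 log units; beyond the scatter) on the amide-type nitrogen. Among these compounds, this is the first readable sign that the group on this nitrogen changes how much compound the cells tolerate, and the change here is towards more being tolerated. Compound 3 sits at a limit of the assay rather than a number, so the full size of the step stays unknown: the limit of > 50000 nM in this assay, at which 2 of the 3 values shown sit.

The swap changes both the ring's substituents and its link to the nitrogen, so the compounds shown cannot separate the chlorines from the loss of the benzyl carbon. A plain phenyl group on this nitrogen would be needed to tell the two apart.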